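Aryl-hydrazone series: bromo-hydroxy aryl in place of methyl

The source may report more compounds than this note shows. Statements on the series, on what has been measured and on what is new or still open speak of the compounds shown alone.

Three hydrazones sharing one core have been measured in a functional assay on MCF7 cells (Homo sapiens) for cytotoxicity, read by MTT assay, with a stated time of 48 h; a higher number here means a weaker inhibitor, a lower number a stronger inhibitor. Compound 1 `O=C(CSc1nnc(-c2ccncc2)o1)N/N=C/c1ccc(F)cc1` gives 13500 nM, compound 2 `O=C(CSc1nnc(-c2ccncc2)o1)N/N=C/c1ccc(O)cc1` gives 11700 nM, and compound 3 `Cc1ccc(/C=N/NC(=O)CSc2nnc(-c3ccncc3)o2)cc1` gives 14700 nM. Every single change among them stays within the scatter: a 1.2-fold lower number from compound 1 to compound 2 (0.06 log units; within the scatter), a 1.1-fold higher number from compound 1 to compound 3 (0.04 log units; within the scatter), a 1.3-fold higher number from compound 2 to compound 3 (0.10 log units; within the scatter). Compound 3 has the highest of the three numbers, yet its gap to compound 1 and to compound 2 is within the scatter, so no order can be read from it.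

Compound 4 `O=C(CSc1nnc(-c2ccncc2)o1)N/N=C/c1cc(Br)ccc1O` is not yet measured. Relative to compound 3 the change is 5-bromo-2-hydroxyphenyl in place of 4-methylphenyl on a carbon with a double bond to nitrogen. Going by the values given here, no measured step covers this exact change; the nearest is the exchange of hydroxy for methyl on the aromatic ring, which moved the number only within the scatter from compound 2 to compound 3. Bromine on the ring has no measured counterpart. On this basis no step beyond the scatter is expected in this assay. Compound 4 is therefore estimated at 12000 nM, with a range of 5000 nM to 30000 nM. The implied step, a 1.2-fold lower number from compound 3 to compound 4 (0.09 log units; within the scatter), is expected to remain within the scatter.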

Compound 4, half-maximal inhibitory concentration: 7770 nM
Compound 4: the middle estimate sits 1.5-fold (0.19 log units) above what was measured; measured number inside the range.
By their numbers in this assay, from the lowest: compounds 4, 2, 1 and 3 (each within the scatter of the next).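

Unlike the exchanges of one substituent among compound 1, compound 2 and compound 3, this change replaces the aryl group on the carbon with a double bond to nitrogen and brings in bromine, and in this assay it gives a 1.9-fold lower number from compound 3 to compound 4 (0.28 log units; within the scatter), a 1.5-fold lower number from compound 2 to compound 4 (0.18 log units; within the scatter) and a 1.7-fold lower number from compound 1 to compound 4 (0.24 log units; within the scatter). All three steps stay within the scatter, so this position accepts 5-bromo-2-hydroxyphenyl without a readable shift, and no order among the four compounds can be drawn. Nothing available explains where these numbers sit.

The compounds shown do not separate the contribution of bromine from that of the hydroxy group in 5-bromo-2-hydroxyphenyl. Going by these compounds, how an amine or a carboxylic acid on the aryl group, or a longer chain in its place, would read in this assay also stays open.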